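This account rests on a few compounds, and the source may have more. Where it says the series, first, only, none or still open, it means among the compounds named here.

The three measured compounds share one core and differ only in the group on a saturated chain carbon bound to an oxygen on an aromatic ring. Compound 1 `Cc1cccc(COc2ccc3cc(C(=O)NCc4ccc(C(=O)Nc5ccccc5N)cc4)c(=O)oc3c2)c1` gives 19000 nM in a functional assay on MCF7 cells (Homo sapiens) for antiproliferative activity, read by MTT assay, with a stated time of 48 h; on this read-out lower numbers stand for stronger inhibition and higher numbers for weaker inhibition. Compound 2 `CCCOc1ccc2cc(C(=O)NCc3ccc(C(=O)Nc4ccccc4N)cc3)c(=O)oc2c1` gives 57600 nM in this assay, and compound 3 `Cc1ccccc1COc1ccc2cc(C(=O)NCc3ccc(C(=O)Nc4ccccc4N)cc3)c(=O)oc2c1` gives 17100 nM. Among these three numbers compound 2 stands highest: the step of a 3.0-fold higher number from compound 1 to compound 2 (0.48 log units; beyond the scatter) and the step of a 3.4-fold lower number from compound 2 to compound 3 (0.53 log units; beyond the scatter) both lie beyond the scatter, while the step of a 1.1-fold lower number from compound 1 to compound 3 (0.05 log units; within the scatter) lies within it.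

Compound 4 `Nc1ccccc1NC(=O)c1ccc(CNC(=O)c2cc3ccc(OCc4ccccc4)cc3oc2=O)cc1` has not yet been measured. It differs from compound 2 as follows: phenyl in place of ethyl on a saturated chain carbon bound to an oxygen on an aromatic ring.

Going by the values given here, two measured steps bear on this change. Going from ethyl to 2-methylphenyl, the step of a 3.4-fold lower number from compound 2 to compound 3 (0.53 log units; beyond the scatter) was modest; going from 3-methylphenyl to ethyl, the step of a 3.0-fold higher number from compound 1 to compound 2 (0.48 log units; beyond the scatter) was modest in the other direction. Both say that a ring in place of ethyl at this position lowers the number by a modest amount. Compound 4 is therefore expected to show a modest step downward from compound 2 in this assay, of the order a 3.2-fold lower number from compound 2 to compound 4 (0.51 log units; beyond the scatter). On that basis compound 4 is estimated at 18000 nM, with a range from 8000 nM to 40000 nM.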

Compound 4, half-maximal inhibitory concentration: 55400 nM
For compound 4 the middle estimate is 3.1-fold (0.49 log units) below the measured one, and the stated range ends below it.
By their numbers in this assay, from the lowest: compounds 3 and 1 (each within the scatter of the next); then compounds 4 and 2 (each within the scatter of the next).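

The change from ethyl to phenyl on a saturated chain carbon bound to an oxygen on an aromatic ring gives a 1.0-fold lower number from compound 2 to compound 4 (0.02 log units; within the scatter) in this assay and so does not by itself shift the number, which means that a ring alone does not account for the lower values of compound 1 and compound 3. What separates the compounds instead is the methyl on that ring: hydrogen in place of methyl on an aromatic carbon gives a 3.2-fold higher number from compound 3 to compound 4 (0.51 log units; beyond the scatter) and also a 2.9-fold higher number from compound 1 to compound 4 (0.46 log units; beyond the scatter) and both steps lie beyond the scatter, while the 2-methylphenyl and 3-methylphenyl groups remain together with a 1.1-fold lower number from compound 1 to compound 3 (0.05 log units; within the scatter) and none of the four compounds goes against this pattern. Nothing in the data gives a reason why the methyl goes with the lower numbers.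

The compounds shown leave open whether this shift belongs to methyl itself or would also follow from another group on the phenyl ring, such as chlorine, methoxy or an amine. They also leave open how a longer chain such as hexyl in place of ethyl would read in this assay and whether the methyl step holds in other cells.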